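Carboxy to hydroxy: working notes on compound 3

The source may hold more compounds than are shown below. What is called first, only, known or untested is meant among the compounds shown, and "the series" means these compounds.

Of the compounds shown here, two have numbers so far: compound 1 (`COC(=O)Cn1c(=O)c(S(=O)(=O)c2ccc(F)cc2F)cc2cnc(Nc3ccc4[nH]ccc4c3)nc21`) and compound 2 (`Cn1c(=O)c(S(=O)(=O)c2ccc(C(=O)O)cc2)cc2cnc(Nc3ccc4[nH]ccc4c3)nc21`). In a functional assay on DU-145 cells (Homo sapiens) for inhibition, read by trypan blue exclusion, with a stated time of 72 h (on this read-out higher numbers stand for weaker inhibition and lower numbers for stronger inhibition), compound 1 gives 10000 nM. In this assay compound 2 gives 10000 nM, level with compound 1, so the two values offer no ranking. Going by the values given here, no step between measured compounds that differ in one place is available to calibrate the next change.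

That change leads to compound 3 (`Cn1c(=O)c(S(=O)(=O)c2ccc(O)cc2)cc2cnc(Nc3ccc4[nH]ccc4c3)nc21`): hydroxy in place of carboxy on an aromatic carbon. Hydroxy stands in place of carboxy on an aromatic carbon, para to a large group. Among the compounds with values here, the only anchor is compound 2 at 10000 nM, so a modest move is expected at most. The expected change, a 2.5-fold lower number from compound 2 to compound 3 (0.40 log units; beyond the scatter), points towards stronger inhibition, only slightly beyond the scatter, and no change remains possible. For compound 3 the estimate is 4000 nM, with an expected range of 700 nM to 10000 nM.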

Compound 3, half-maximal inhibitory concentration: 250 nM
For compound 3 the middle estimate is 16-fold (1.20 log units) above the measured one, and the stated range ends above it.
By their numbers in this assay, from the lowest: compound 3; then compounds 1 and 2 (each within the scatter of the next).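

In this assay, going by these compounds alone, the change from 4-carboxyphenyl to 4-hydroxyphenyl gives a 40-fold lower number from compound 2 to compound 3 (1.60 log units; beyond the scatter) and is the only step so far that can be read. This aromatic carbon, para to a large group, is therefore not a silent position: the two compounds differ in this one place, and that difference alone separates them widely. The level values of compound 1 and compound 2 gave no sign of this, whereas compound 3 now provides a clear reference point for further changes here.

On these data alone, whether the step depends on the hydroxy entering or the carboxy leaving stays open, and a methoxy group, an amine or a fluorine at the same carbon would help to separate the two. Nothing available explains the size of this step.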